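From Methylbenzyl to Chlorobenzyl in a Cytotoxicity Series

A few compounds are considered here, and "the series" means these few. Any claim that something is new, unique, unknown or untested is made for them only; others in the source may bear on it.

Compound 1 `O=[N+]([O-])c1cc(Sc2nnnn2Cc2ccccc2)cc([N+](=O)[O-])c1`: 127000 nM in an ADME assay on CHO-K1 cells (Cricetulus griseus) for cytotoxicity, read by MTT assay, with a stated time of 24 h; a lower number here means a stronger inhibitor, a higher number a weaker inhibitor
Compound 2 `O=[N+]([O-])c1cc(Sc2nnnn2C2CCCCC2)cc([N+](=O)[O-])c1`: 153000 nM
Compound 3 `Cc1ccc(Cn2nnc(-c3cc([N+](=O)[O-])cc([N+](=O)[O-])c3)n2)cc1`: 200000 nM

Compound 3 gives the highest of the three numbers in this assay, though its separation from compound 2 and from compound 1 lies within the scatter. The change to compound 4 `O=[N+]([O-])c1cc(-c2nnn(Cc3cccc(Cl)c3)n2)cc([N+](=O)[O-])c1` is 3-chlorophenyl in place of 4-methylphenyl on a saturated chain carbon bound to an aromatic nitrogen. Within the data shown here, no measured step covers this change. Among the measured compounds shown here, the one measured step, a 1.2-fold higher number from compound 1 to compound 2 (0.08 log units; within the scatter), concerns a different position and was within the scatter, so it offers only the hint that the group on that arm has changed the number little. A step of no more than the scatter is therefore expected for a 1.1-fold lower number from compound 3 to compound 4 (0.02 log units; within the scatter). Compound 4 is estimated to give 190000 nM, with a range from 95000 nM to 380000 nM.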

Compound 4, half-maximal inhibitory concentration: 27000 nM
Beside the measured number, compound 4's estimate is 7.0-fold (0.85 log units) above it, and the stated range ends above it.
By their numbers in this assay, from the lowest: compound 4; then compounds 1, 2 and 3 (each within the scatter of the next).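

In this assay, among these compounds, the group on a saturated chain carbon bound to an aromatic nitrogen can move the number beyond the scatter, with a 7.4-fold lower number from compound 3 to compound 4 (0.87 log units; beyond the scatter), whereas the only earlier step stayed within it. 4-Methylphenyl and 3-chlorophenyl have the same count of heavy atoms and the same kind of ring, yet the numbers differ. No evidence bears on the reason for this step.

As far as these compounds go, whether the lower number belongs to the chlorine or to its place on the ring remains open. So does the effect of an amine or a carboxylic acid on that ring.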